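Shifting the aryl group on the ring nitrogen

This account rests on a few compounds, and the source may have more. Where it says the series, first, only, none or still open, it means among the compounds named here.

Measured compounds:
Compound 1 `Nc1scc(CN2CCN(c3cc(Cl)cc(Cl)c3)CC2)c1C(=O)c1ccc(Cl)cc1` with -69%
Compound 2 `Nc1scc(CN2CCN(c3ccc(OC(F)(F)F)cc3)CC2)c1C(=O)c1ccc(Cl)cc1` with -51%
Compound 3 `Nc1scc(CN2CCN(c3c(F)cccc3F)CC2)c1C(=O)c1cccc(C(F)(F)F)c1` with 1.3%

In a functional assay on CHO cells with adenosine receptor A1 (Homo sapiens) as the target, read by cAMP accumulation and immunoassay, with a stated time of 6 min, tested at 1 uM (a lower number here means a stronger effect, a higher number a weaker effect of the compound at the concentration tested), compound 2 gives -51%, the second highest of the three numbers. Its nearest neighbour is compound 1, whose value -69% lies lower by a margin beyond the scatter; compound 3 stands furthest away at 1.3%.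

The unmeasured compound 4 `Nc1scc(CN2CCN(c3cccc(F)c3F)CC2)c1C(=O)c1ccc(Cl)cc1` differs from compound 2 in one place: 2,3-difluorophenyl in place of 4-(trifluoromethoxy)phenyl on an amine nitrogen in a ring. Among the measured compounds shown here, one measured step bears on this: a number 18 percentage points higher from compound 1 to compound 2 (beyond the scatter), where the aryl group on the same ring nitrogen was exchanged. For the measured compounds named here, compound 3 also carries a difluorophenyl on that nitrogen, but it also differs from compound 2 at the ketone, so no single step connects it; its value only shows that such a combination gave a much weaker effect.

Since a change at this position has already moved the number by a modest amount, and compound 3 points toward weaker effects with a difluorophenyl, compound 4 is expected to sit somewhat higher than compound 2, an estimated step of a number 16 percentage points higher from compound 2 to compound 4 (beyond the scatter). The estimate for compound 4 is -35%, within the range -65% to 0%.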

Compound 4, a percentage reported as activity, at one concentration (the size of the read-out at that concentration, not a potency): -66%
Estimate against measurement, compound 4: 31 percentage points above; the measured number lies below the stated range.
By their numbers in this assay, from the lowest: compounds 1 and 4 (each within the scatter of the next); then compound 2; then compound 3.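

In this assay, putting 2,3-difluorophenyl on the ring nitrogen gives a number 15 percentage points lower from compound 2 to compound 4 (beyond the scatter), so this position can move the number down as well as up, against the rise seen in a number 18 percentage points higher from compound 1 to compound 2 (beyond the scatter). The same group set against 3,5-dichlorophenyl gives a number 3 percentage points higher from compound 1 to compound 4 (within the scatter), so two aryl groups with different halogens read alike here, and of the three aryl groups on this nitrogen with the same ketone, 4-(trifluoromethoxy)phenyl alone stands apart. Nothing available explains why these aryl groups fall as they do.

From the compounds shown here alone, it remains open how an aryl group carrying an amine, a carboxylic acid or a nitrile would read on this nitrogen. Going by these compounds, it also remains open whether these steps would hold with a different aryl group on the ketone.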